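The source may report more compounds than this note shows. Statements on the series, on what has been measured and on what is new or still open speak of the compounds shown alone.

Measured compounds:
Compound 1 `CCC[C@H](CCO)Nc1nc(N)nnc1OCc1nccc(OC)c1OC` — 560 nM
Compound 2 `CCCCNc1nc(N)nnc1OCCCN(C)C` — 100 nM
Compound 3 `CCCCNc1nc(N)nnc1OC` — 2040 nM

Compound 2 gives the lowest number of the three in an assay on isolated protein for agonist activity at Toll-like receptor 8 (Homo sapiens); a lower number here means that less compound is needed, a higher number that more compound is needed for the effect; compound 1 sits nearest to it and compound 3 furthest, both beyond the scatter. The compound not yet measured is compound 4 `CCCCNc1nc(N)nnc1OCc1ccccc1`, which differs from compound 2 in one place: phenyl in place of 2-(dimethylamino)ethyl on a saturated chain carbon bound to an oxygen on an aromatic ring. Going by the values given here, only one measured step touches this position, and it is large: a 20-fold higher number from compound 2 to compound 3 (1.31 log units; beyond the scatter), where the whole 2-(dimethylamino)ethyl group is cut back to hydrogen. Compound 4 keeps a substituent on that chain carbon, but a phenyl brings no hydrogen-bond acceptor where the departing group held one. Compound 1, which carries a substituted aromatic ring at the same oxygen together with a different side chain on the amine, gives 560 nM, well above compound 2 yet well below compound 3. The expectation is therefore a step upward in this assay of middling size, an 8.0-fold higher number from compound 2 to compound 4 (0.90 log units; beyond the scatter), smaller than the loss seen on going to hydrogen. For compound 4 a value of about 800 nM is estimated, with a range from 250 nM to 2500 nM.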

Compound 4, half-maximal effective concentration: 1930 nM
Compound 4: the middle estimate sits 2.4-fold (0.38 log units) below what was measured; the measured number falls inside the stated range.
By their numbers in this assay, from the lowest: compound 2; then compound 1; then compounds 4 and 3 (each within the scatter of the next).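

In this assay, replacing 2-(dimethylamino)ethyl with phenyl gives a 19-fold higher number from compound 2 to compound 4 (1.29 log units; beyond the scatter), so a six-membered aromatic ring on the saturated chain carbon does not keep the low number that compound 2 shows. The earlier step to hydrogen could not show whether any substituent there would hold that number, but this comparison separates phenyl from hydrogen by no more than a 1.1-fold lower number from compound 3 to compound 4 (0.02 log units; within the scatter), and in this pair the ring gives no measurable gain over having no substituent at all. Among these three compounds with the butylamino side chain, only the one with 2-(dimethylamino)ethyl stands apart, and nothing available here explains why phenyl and hydrogen end up alike.

The compounds shown leave open whether the dimethylamino nitrogen or the carbon chain that carries it accounts for the low number of compound 2, a question that a plain propyl chain or a longer chain ending in a dimethylamino group at this place would address. Compound 1 differs from compound 2 in more than one place, so the contribution of its substituted aromatic ring cannot be read apart from that of its amine side chain.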